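The compounds below may be only part of what the source reports. "The series", "measured", "known", "first", "only" and "open" are said of these compounds alone.

Compound 1 `Nc1ccccc1NC(=O)c1ccc(CSC(=S)N2CCc3ccccc32)cc1`, compound 2 `Nc1ccccc1NC(=O)c1ccc(CSC(=S)N2CCN(c3cccnc3)CC2)cc1` and compound 3 `Nc1ccccc1NC(=O)c1ccc(CSC(=S)N(Cc2ccccc2)Cc2ccccc2)cc1` share one core and differ only in the amine that carries the dithiocarbamate. In a functional assay on HeLa cells (Homo sapiens) for antiproliferative activity, read by CCK-8 assay, with a stated time of 72 h, tested at 8 uM (a lower number here means a weaker effect, a higher number a stronger effect of the compound at the concentration tested), compound 1 gives 67%, compound 2 gives 72.5% and compound 3 gives 18.9%. Compound 2 thus shows the highest of the three numbers; the number of compound 1 lies close to it, within the usual scatter, while the number of compound 3 lies well below it, beyond the scatter. Compound 4 `Nc1ccccc1NC(=O)c1ccc(CSC(=S)N2CCN(c3ccccc3F)CC2)cc1` has not yet been tested. It differs from compound 2 in one place: 2-fluorophenyl in place of pyridin-3-yl on an amine nitrogen in a ring. Among the compounds with values here, no pair of measured compounds differing in a single place is available, so the size of this step is not known from a direct comparison. Since compound 2 gives 72.5% and compound 1, which also carries a ring amine, gives 67%, the step from one aryl amine in a ring to another is expected to be small, and the expected change a number 7.5 percentage points lower from compound 2 to compound 4 (within the scatter) is estimated to stay within the scatter. Compound 4 is therefore expected to give about 65%, with a range from 45% to 80%.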

Compound 4, a percentage reported as inhibition, at one concentration (the size of the read-out at that concentration, not a potency): 59.2%
Estimate against measurement, compound 4: 5.8 percentage points above; measured number inside the range.
By their numbers in this assay, from the lowest: compound 3; then compounds 4, 1 and 2 (each within the scatter of the next, the first and the last beyond it).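

In this assay, placing 2-fluorophenyl instead of pyridin-3-yl on the amine nitrogen in the ring gives a number 13.3 percentage points lower from compound 2 to compound 4 (beyond the scatter). Within the data shown here, this is the first direct comparison at this position, and it shows that the choice of aromatic ring there changes the read-out, though modestly: compound 4 still gives 59.2%. No measurement at hand accounts for the size or direction of this step.

From the compounds shown here alone, the step swaps the ring nitrogen of pyridin-3-yl and adds a fluorine in a single change, so the contribution of each stays open; a plain phenyl group at the same place would separate the two. Also open, going by these compounds, is how the read-out would respond if a methyl group or a short alkyl chain took the place of the aromatic ring on this nitrogen.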